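Swapping a Benzyl Arm for a Short Amine Chain

The compounds below may be only part of what the source reports. "The series", "measured", "known", "first", "only" and "open" are said of these compounds alone.

Compound 1 `COc1ccc(CNc2cc(Oc3ccc(NC(=O)Nc4ccc(C)c(C(F)(F)F)c4)cc3)ncn2)cc1` is one of two measured compounds. In a functional assay on BaF3 cells (Mus musculus) for inhibition, read by CCK-8 assay, with a stated time of 72 h (a higher number here means a weaker inhibitor of growth, a lower number a stronger inhibitor of growth), compound 1 gives 1000 nM. Compound 2 `C=CC(=O)Nc1cc(Oc2ccc(NC(=O)Nc3ccc(C)c(C(F)(F)F)c3)cc2)ncn1` gives 1940 nM in this assay, and the step of a 1.9-fold higher number from compound 1 to compound 2 (0.29 log units; within the scatter) keeps the pair within the usual scatter, so neither can be called stronger. Compound 3 `Cc1ccc(NC(=O)Nc2ccc(Oc3cc(NCCN)ncn3)cc2)cc1C(F)(F)F` is unmeasured and differs from compound 1 by aminomethyl in place of 4-methoxyphenyl on a saturated chain carbon bound to a nitrogen on an aromatic ring. Going by the values given here, only the step from compound 1 to compound 2 bears on this change, as it also replaces the 4-methoxybenzyl group, and it stayed within the scatter. Compound 3 is therefore expected to give 1500 nM, between 400 nM and 5000 nM, an expected step of a 1.5-fold higher number from compound 1 to compound 3 (0.18 log units; within the scatter).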

Compound 3, concentration for 50% growth inhibition: > 10000 nM
Compound 3 ended at the assay's limit (the forecaster's own chance of this, stated with the estimate: 5%); middle value at least 6.6-fold (0.82 log units) from the limit.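

In this assay compound 3 gives > 10000 nM, which is a limit of the assay and not a number. The group on this nitrogen can clearly matter: 2-aminoethyl brings an at least 10-fold higher number from compound 1 to compound 3 (1.00 log units; beyond the scatter), and it brings an at least 5.1-fold higher number from compound 2 to compound 3 (0.71 log units; beyond the scatter), so this change costs far more than the earlier swap of 4-methoxybenzyl for vinylcarbonyl. The position therefore does not tolerate every replacement.

Going by these compounds, whether the amine or the short chain drives this loss stays open. A 2-hydroxyethyl group or a longer chain such as 3-aminopropyl could separate the two.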